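The source may hold more compounds than are shown below. What is called first, only, known or untested is meant among the compounds shown, and "the series" means these compounds.

In a functional assay on the whole organism for inhibition, with Rattus norvegicus as the target, read by paw edema (on this read-out higher numbers stand for an effect only at larger amounts of compound and lower numbers for an effect already at smaller amounts), compound 1 `O=C(O)c1cc(-n2cccc2)ccc1O` gives 50 mg/kg, the lowest of the two numbers recorded. Compound 2 `O=C(O)c1cc(-c2cocn2)ccc1O` gives 110 mg/kg, with a 2.2-fold higher number from compound 1 to compound 2 (0.34 log units; beyond the scatter). Compound 3 `O=C(O)c1cc(-c2csnn2)ccc1O` reaches only a limit in this assay, > 200 mg/kg. Compound 4 `CCCCOC(=O)Oc1ccc(-n2cccc2)cc1C(=O)O` differs from compound 1 by butoxycarbonyl in place of hydrogen on an oxygen on an aromatic ring. Going by the values given here, none of the measured steps alters the group on that oxygen: a 2.2-fold higher number from compound 1 to compound 2 (0.34 log units; beyond the scatter), an at least 4.0-fold higher number from compound 1 to compound 3 (0.60 log units; beyond the scatter) and an at least 1.8-fold higher number from compound 2 to compound 3 (0.25 log units; that floor lies within the scatter) all exchange the ring on the aromatic carbon, so they do not bear on this change, and no step beyond the scatter is expected in this assay. Compound 4 is therefore estimated at 60 mg/kg, between 25 mg/kg and 150 mg/kg, which is expected to mean a 1.2-fold higher number from compound 1 to compound 4 (0.08 log units; within the scatter).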

Compound 4, dose for half-maximal effect: 52 mg/kg
The estimate for compound 4 lay 1.2-fold (0.06 log units) above the measured number; the range from low to high includes it.
By their numbers in this assay, from the lowest: compounds 1 and 4 (each within the scatter of the next); then compound 2. At a limit, above all of these: compound 3.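

In this assay, butoxycarbonyl in place of hydrogen on the oxygen on the aromatic ring gives a 1.0-fold higher number from compound 1 to compound 4 (0.02 log units; within the scatter) and so leaves the number within the scatter. The earlier steps shown here changed only the ring on the aromatic carbon, whereas this one shows that the oxygen can carry a chain of this size without a measurable change in this read-out. Nothing shown accounts for this result.

Still open, on these data alone, is how an acetyl group, a methyl ether or a longer chain on that oxygen would read. Also open, as far as these compounds go, is whether butoxycarbonyl has the same effect on compound 2.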